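From fluoro to methoxy: the step to compound 4

A few compounds are considered here, and "the series" means these few. Any claim that something is new, unique, unknown or untested is made for them only; others in the source may bear on it.

Measured so far in a functional assay on HeLa cells (Homo sapiens) for cytotoxicity, read by MTT assay, with a stated time of 2 days; a lower number here means a stronger inhibitor, a higher number a weaker inhibitor:
Compound 1 `Cc1cccc(-c2nc3cc(C)ccc3c(=O)[nH]2)c1` gives 11200 nM
Compound 2 `COc1cccc(-c2nc3ccc(C)cc3c(=O)[nH]2)c1` gives > 50000 nM as a limit
Compound 3 `Cc1ccc2c(=O)[nH]c(-c3cccc(F)c3)nc2c1` gives > 50000 nM as a limit

Compound 3 has no exact number, only a limit. It stands at the limit of > 50000 nM in this assay, at which 2 of the 3 values shown sit, and compound 2 is the other compound there.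

Compound 4 `COc1cccc(-c2nc3cc(C)ccc3c(=O)[nH]2)c1` shares the core of compound 3. The change is counted as methoxy in place of fluoro on an aromatic carbon and is methoxy in place of fluoro on an aromatic carbon, meta to a large group.

Among the compounds with values here, one measured step bears directly on this place. It is an at least 4.4-fold higher number from compound 1 to compound 3 (0.64 log units; beyond the scatter) and it came with fluoro in place of methyl on an aromatic carbon. Compound 1 thus shows with 11200 nM that this core can give a real number when fluoro is absent. On a core not quite that of compound 4, compound 2 also bears a methoxy group, and its > 50000 nM is a limit, which argues against a large gain.

A modest move towards a lower number in this assay is therefore expected, though it may not be measurable. The estimated change is an at least 1.6-fold lower number from compound 3 to compound 4 (0.22 log units; that floor lies within the scatter) and it remains uncertain. For compound 4 the estimated value is 30000 nM with a range from 10000 nM to 80000 nM and a real chance of another limit.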

Compound 4, half-maximal inhibitory concentration: 8940 nM
Compound 4: the middle estimate sits 3.4-fold (0.53 log units) above what was measured; measured number below the stated range.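

On the shared core, methoxy in place of fluoro on an aromatic carbon, meta to a large group, turns a limit into a real number in this assay, with an at least 5.5-fold lower number from compound 3 to compound 4 (0.74 log units; beyond the scatter). Methoxy and methyl at this place cannot be told apart, with a 1.3-fold lower number from compound 1 to compound 4 (0.10 log units; within the scatter), so among the three compounds on this core, compound 3 with its fluoro is the one set apart from the other two. Compound 2, which also bears methoxy on a core not quite that of compound 4, remains a limit and not a number, so a measurable value does not come with the methoxy group alone, and compound 2 stays at: the limit of > 50000 nM in this assay, at which 2 of the 4 values shown sit.

Whether the value at this place depends on the particular group or only on the absence of fluoro stays open, as just methyl, methoxy and fluoro are shown there. Going by these compounds, how a hydroxyl, an amine or a longer chain such as ethoxy would fare at this place is unknown. The two methoxy compounds part ways, and the data offer no explanation for this.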